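The source may hold more compounds than are shown below. What is called first, only, known or untested is meant among the compounds shown, and "the series" means these compounds.

In a functional assay on MDA-MB-468 cells (Homo sapiens) for antiproliferative activity, read by MTT assay, with a stated time of 48 h (a higher number here means a weaker inhibitor, a lower number a stronger inhibitor), compound 2 (`CN(C)CCNc1cc2c(cn1)cc(NC(=O)c1ccc(Cl)cc1)c(=O)n2C`) gives 1640 nM, the lower of the two numbers, while compound 1 (`CN(C)CCNc1cc2c(cn1)cc(NC(=O)/C=C/c1ccccc1)c(=O)n2C`) gives 12100 nM. Compound 3 (`CN(C)CCNc1cc2c(cn1)cc(NC(=O)c1ccccc1)c(=O)n2C`) keeps the core of compound 2 and carries hydrogen in place of chloro on an aromatic carbon. For the measured compounds named here, the only measured step, a 7.4-fold lower number from compound 1 to compound 2 (0.87 log units; beyond the scatter), replaces the whole group on the carbonyl carbon, so it bears on this smaller change only indirectly. A modest rise is therefore expected in this assay, an estimated step of a 1.7-fold higher number from compound 2 to compound 3 (0.23 log units; within the scatter). The expected value for compound 3 is 2800 nM, with an estimated range of 1100 nM to 7000 nM.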

Compound 3, half-maximal inhibitory concentration: 18300 nM
The estimate for compound 3 lay 6.5-fold (0.82 log units) below the measured number, outside the stated range (above it).
By their numbers in this assay, from the lowest: compound 2; then compounds 1 and 3 (each within the scatter of the next).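

In this assay, the chloro para to a large group accounts for a large difference on its own, as its loss gives an 11-fold higher number from compound 2 to compound 3 (1.05 log units; beyond the scatter) on an otherwise unchanged structure. The step of a 1.5-fold higher number from compound 1 to compound 3 (0.18 log units; within the scatter) does not separate phenyl from 2-phenylethenyl on the carbonyl carbon, so the lower number of compound 2 is tied to the chloro rather than to the change to a benzoyl group. Nothing given here explains the size of this difference. As far as these compounds go, whether fluoro, bromo or methoxy at the same place would match the chloro remains open. So does the effect of moving the chloro elsewhere on the ring.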